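Swapping methyl for fluoro on the sulfonyl aryl ring

The compounds below may be only part of what the source reports. "The series", "measured", "known", "first", "only" and "open" are said of these compounds alone.

Measured compounds:
- Compound 1, `Cc1ccc(C(=O)N2N=C(c3ccc(N4CCN(C)CC4)cc3)CC2c2ccc(N(C)C)cc2)cc1`: -2.5%
- Compound 2, `Cc1ccc(S(=O)(=O)N2N=C(c3ccc(N4CCN(C)CC4)cc3)CC2c2ccc(N(C)C)cc2)cc1`: 32.2%

In a functional assay on HCC1806 cells (Homo sapiens) for inhibition, read by sulforhodamine B assay, tested at 10 uM (on this read-out lower numbers stand for less inhibition and higher numbers for more inhibition at the one concentration tested (going by the name of the read-out)), compound 1 gives -2.5%, while compound 2 gives 32.2%. Going by the values given here, compound 2 stands highest of the two numbers measured; the only step recorded is a number 34.7 percentage points higher from compound 1 to compound 2 (beyond the scatter), in which (4-methylphenyl)sulfonyl replaces (4-methylphenyl)carbonyl on an amine nitrogen in a ring.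

Compound 3, `CN1CCN(c2ccc(C3=NN(S(=O)(=O)c4ccc(F)cc4)C(c4ccc(N(C)C)cc4)C3)cc2)CC1`, keeps the sulfonyl of compound 2 and differs from it only by fluoro in place of methyl on an aromatic carbon. Among the compounds with values here, no measured step touches the ring that carries this group, so nothing in the data speaks for a shift beyond the scatter in this assay. Compound 3 is therefore expected to stay close to compound 2, with an estimated step of a number 2.2 percentage points lower from compound 2 to compound 3 (within the scatter). The estimate for compound 3 is 30%, in a range from 10% to 50%.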

Compound 3, a percentage reported as inhibition, at one concentration (the size of the read-out at that concentration, not a potency): 92.3%
Estimate against measurement, compound 3: 62.3 percentage points below, outside the stated range (above it).
By their numbers in this assay, from the lowest: compound 1; then compound 2; then compound 3.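

In this assay, going by these compounds alone, the aromatic carbon on the sulfonyl aryl ring proves to be a sensitive position, one the earlier compounds had not probed: fluoro in place of methyl, a swap of one heavy atom for one, gives a number 60.1 percentage points higher from compound 2 to compound 3 (beyond the scatter). The earlier step had shown that the sulfonyl matters, and this one shows that the group on its aryl ring matters too. Replacing the whole (4-methylphenyl)carbonyl with (4-fluorophenyl)sulfonyl gives a number 94.8 percentage points higher from compound 1 to compound 3 (beyond the scatter), which makes compound 3 the highest of the three. Nothing available explains the size of this step.

The compounds shown leave open whether chloro, methoxy or nitrile on the same carbon would behave like fluoro or like methyl. They also leave open whether fluoro would lift the carbonyl series in the same way.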